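The compounds below may be only part of what the source reports. "The series", "measured", "known", "first", "only" and "open" are said of these compounds alone.

Compound 1 `CS(=O)(=O)c1ccc(Cc2nnc3n2N=C(c2ccccc2)CS3)cc1`: 25000 nM
Compound 2 `Cc1ccc(C2=Nn3c(Cc4ccc(S(C)(=O)=O)cc4)nnc3SC2)cc1`: > 100000 nM

Going by the values given here, in a functional assay on HT-29 cells (Homo sapiens) for cytotoxicity, read by MTT assay, with a stated time of 48 h (on this read-out higher numbers stand for weaker inhibition and lower numbers for stronger inhibition), compound 1 gives 25000 nM, the only actual number so far. Compound 2 gives > 100000 nM, which is a limit. Compound 3 `CS(=O)(=O)c1ccc(Cc2nnc3n2N=C(c2ccc(O)c(C(N)=O)c2)CS3)cc1` keeps the core of compound 1 and carries 3-carbamoyl-4-hydroxyphenyl in place of phenyl on a carbon with a double bond to nitrogen. Among the compounds with values here, the one measured step, an at least 4.0-fold higher number from compound 1 to compound 2 (0.60 log units; beyond the scatter), also changes that phenyl, by methyl in place of hydrogen, and lies beyond the scatter. It is a much smaller change, so it offers only a loose guide, and no direction follows from it. The expected change is therefore small and uncertain, estimated as a 1.4-fold lower number from compound 1 to compound 3 (0.14 log units; within the scatter). For compound 3 the estimate is 18000 nM, expected within 4000 nM to 80000 nM.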

Compound 3, half-maximal inhibitory concentration: > 100000 nM
Compound 3: a limit, no number (the forecaster's own chance of this, stated with the estimate: 20%); middle value at least 5.5-fold (0.74 log units) from the limit.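

In this assay, 3-carbamoyl-4-hydroxyphenyl on this carbon gives an at least 4.0-fold higher number from compound 1 to compound 3 (0.60 log units; beyond the scatter). So a second, much larger change to the phenyl moves the read-out the same way as the methyl did, and of the three groups shown here only the plain phenyl of compound 1 gives an actual number. Compound 2 and compound 3 each end at a limit, so the step between them cannot be read: the limit of > 100000 nM in this assay, at which 2 of the 3 values shown sit.

Going by these compounds, it remains open whether fluorine or methoxy on this phenyl would give a number, and whether any group here would lower the value of compound 1.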